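From Isopropyl to 3-Hydroxypropyl on the Amide Side Chain

The compounds below may be only part of what the source reports. "The series", "measured", "known", "first", "only" and "open" are said of these compounds alone.

In a functional assay on MCF7 cells (Homo sapiens) for antiproliferative activity, read by MTT assay, with a stated time of 24 h (a higher number here means a weaker inhibitor, a lower number a stronger inhibitor), three compounds sharing one core have been measured. Compound 1 `CCN(CC)CCNC(=O)c1ccc(C(CC)(CC)c2ccc(OCS(=O)(=O)c3ccccc3)c(C)c2)n1CC` reads 4680 nM with 2-(diethylamino)ethyl on the amide-type nitrogen. Compound 2 `CCn1c(C(=O)NC(C)(C)CO)ccc1C(CC)(CC)c1ccc(OCS(=O)(=O)c2ccccc2)c(C)c1` reads 20700 nM with 1-(hydroxymethyl)-1-methylethyl in that place, and compound 3 `CCn1c(C(=O)N[C@H](CO)C(C)C)ccc1C(CC)(CC)c1ccc(OCS(=O)(=O)c2ccccc2)c(C)c1` reads 25500 nM with 1-(hydroxymethyl)-2-methylpropyl. Compound 3 thus sits level with compound 2 at the weak end of this small set, clearly apart from compound 1.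

Compound 4 `CCn1c(C(=O)N[C@H](CO)CCCO)ccc1C(CC)(CC)c1ccc(OCS(=O)(=O)c2ccccc2)c(C)c1` differs from compound 3 in one group (3-hydroxypropyl in place of isopropyl on a saturated chain carbon bound to an amide-type nitrogen and a saturated chain carbon): 3-hydroxypropyl in place of isopropyl on a saturated chain carbon bound to an amide-type nitrogen and a saturated chain carbon. Replacing the 2-(diethylamino)ethyl group gave a 4.4-fold higher number from compound 1 to compound 2 (0.65 log units; beyond the scatter) and a 5.4-fold higher number from compound 1 to compound 3 (0.74 log units; beyond the scatter) but that exchange does not recur here. The nearer guide is a 1.2-fold higher number from compound 2 to compound 3 (0.09 log units; within the scatter) for one hydroxymethyl-bearing group swapped for another. Within the data shown here, no measured compound carries a 3-hydroxypropyl group, so this guide is indirect. A step within the scatter is therefore expected in this assay with no clear direction, and the estimated step is a 1.1-fold higher number from compound 3 to compound 4 (0.02 log units; within the scatter) in size. Compound 4 is estimated at 27000 nM (expected range 13000 nM to 55000 nM).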

Compound 4, half-maximal inhibitory concentration: 31400 nM
The estimate for compound 4 lay 1.2-fold (0.07 log units) below the measured number; the measured number falls inside the stated range.
By their numbers in this assay, from the lowest: compound 1; then compounds 2, 3 and 4 (each within the scatter of the next).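

Swapping isopropyl for 3-hydroxypropyl on a saturated chain carbon bound to an amide-type nitrogen and a saturated chain carbon adds a hydroxyl to the side chain, yet in this assay the swap gives a 1.2-fold higher number from compound 3 to compound 4 (0.09 log units; within the scatter), so at this position the added hydrogen-bond donor and acceptor bring no reading beyond the scatter. The wider group on the amide-type nitrogen likewise leaves the reading close to that of the smaller hydroxymethyl-bearing group, with a 1.5-fold higher number from compound 2 to compound 4 (0.18 log units; within the scatter), and the earlier separation from the 2-(diethylamino)ethyl compound holds for this third hydroxyl-bearing group, at a 6.7-fold higher number from compound 1 to compound 4 (0.83 log units; beyond the scatter) as a modest step. Nothing measured on these compounds gives a reason for either the flat reading or that separation.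

Still open, as far as these compounds go, is whether a plain propyl or a longer chain at that carbon, or an amine or a carboxylic acid at the end of the 3-hydroxypropyl chain, would read any differently from the hydroxyl. Also open, from the compounds shown here alone, is whether the diethylamino group alone sets compound 1 apart, which a dimethylamino or a piperidine group on the same ethyl chain could help to test.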